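Removing One Ring Hydroxy From a Dihydroxyproline Mimetic

This account rests on a few compounds, and the source may have more. Where it says the series, first, only, none or still open, it means among the compounds named here.

Among the measured compounds shown here, compound 2 `CCOC(=O)[C@@H](NC(=O)[C@@H]1[C@@H](O)[C@@H](O)CN1C(=O)CCCC(=O)O)[C@@H](C)O[C@@H]1O[C@@H](C)[C@@H](O)C(O)C1O` is the stronger of the two compounds measured so far in an assay on isolated protein for inhibition of E-selectin (Homo sapiens); a lower number here means a stronger inhibitor, a higher number a weaker inhibitor: compound 2 gives 50000 nM, whereas compound 1 `CCOC(=O)[C@@H](NC(=O)[C@H](NC(=O)CCCC(=O)O)[C@@H](O)CO)[C@@H](C)O[C@@H]1O[C@@H](C)[C@@H](O)C(O)C1O` gives 500000 nM in this assay, a gap beyond the usual scatter. Compound 3 `CCOC(=O)[C@@H](NC(=O)[C@@H]1C[C@@H](O)CN1C(=O)CCCC(=O)O)[C@@H](C)O[C@@H]1O[C@@H](C)[C@@H](O)C(O)C1O` has not yet been measured. It differs from compound 2 in one place: hydrogen in place of hydroxy on a saturated ring carbon. For the measured compounds named here, no measured pair shows this change, so the size of its effect is unknown. The ring of compound 2 carries two hydroxy groups and the ring of compound 1 none, while compound 3 keeps only one of them; the step of a 1.8-fold higher number from compound 2 to compound 3 (0.26 log units; within the scatter) is therefore estimated to be a modest weakening, possibly still within the scatter. Compound 3 is expected to give about 90000 nM, within a range from 25000 nM to 400000 nM.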

Compound 3, half-maximal inhibitory concentration: 300000 nM
For compound 3 the middle estimate is 3.3-fold (0.52 log units) below the measured one; the measured number falls inside the stated range.
By their numbers in this assay, from the lowest: compound 2; then compounds 3 and 1 (each within the scatter of the next).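

Removing this single hydroxy group gives a 6.0-fold higher number from compound 2 to compound 3 (0.78 log units; beyond the scatter) in this assay, a step beyond the scatter. This is the first measured pair among these compounds that differs in one place, so the hydroxy on this saturated ring carbon, two ring bonds from the ring nitrogen, now has a measured contribution of its own. Keeping the other ring hydroxy in compound 3 does not preserve the number seen with compound 2, and no measurement available here explains the size of this step.

The compounds shown leave open whether the remaining ring hydroxy carries a similar weight when it is removed alone. They also leave open how an amine, a methoxy group or a fluorine on this ring carbon would compare with the hydroxy and the hydrogen.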